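Bromo to chloro swap on two related cores

This account rests on a few compounds, and the source may have more. Where it says the series, first, only, none or still open, it means among the compounds named here.

Measured in a functional assay on SW1573 cells (Homo sapiens) for inhibition, read by sulforhodamine B assay, with a stated time of 48 h; on this read-out lower numbers stand for stronger inhibition of growth and higher numbers for weaker inhibition of growth:
compound 1, `COC(=O)[C@@]1(C)CCC=C2[C@@H]1CC[C@@H](C)[C@]2(C)Cc1c(C)[nH]c2c(Br)cccc12`: 25000 nM
compound 2, `COC(=O)[C@@]1(C)CCC=C2[C@@H]1CC[C@@H](C)[C@]2(C)Cc1c(C)[nH]c2c(Cl)cccc12`: 19000 nM
compound 3, `COC(=O)[C@@]1(C)CC[C@@H]2C3=C1CC[C@@H](C)[C@]3(C)C[C@@H]1c3cc(Br)ccc3N[C@H]21`: 45000 nM

Compound 1 and compound 2 share a core and differ only by chloro in place of bromo on an aromatic carbon. The step is a 1.3-fold lower number from compound 1 to compound 2 (0.12 log units; within the scatter), so the two are not told apart here. Compound 3 carries a different core; the difference between the two cores is not broken down here. Compound 3 has the highest number of the three, but its gap to compound 1 is within the scatter, while against compound 2 it lies beyond it.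

Compound 4, `COC(=O)[C@@]1(C)CC[C@@H]2C3=C1CC[C@@H](C)[C@]3(C)C[C@@H]1c3cc(Cl)ccc3N[C@H]21`, is not yet measured. It differs from compound 3 by chloro in place of bromo on an aromatic carbon. This is the same kind of change as that from compound 1 to compound 2, not the same: in compound 1 the aromatic carbon sits in a fused system of two rings, ortho to a fused ring and meta to a fused ring, whereas in compound 3 it sits in a fused system of five rings, meta to a fused ring and para to a fused ring.

Among the compounds with values here, on the single earlier example, the change is expected to move the number little: the step from compound 3 to compound 4 is estimated as a 1.3-fold lower number from compound 3 to compound 4 (0.11 log units; within the scatter), resting on compound 1 to compound 2 showing a 1.3-fold lower number from compound 1 to compound 2 (0.12 log units; within the scatter). Compound 4 is therefore expected at 35000 nM, with a range of 15000 nM to 80000 nM. Weak compounds of this kind may also return only a limit.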

Compound 4, concentration for 50% growth inhibition: 38000 nM
Compound 4: middle estimate off by 1.1-fold (0.04 log units), on the low side; the range from low to high includes it.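

In this assay, swapping bromo for chloro on the core of the newly measured pair gives a 1.2-fold lower number from compound 3 to compound 4 (0.07 log units; within the scatter), so the two compounds are not told apart. Set beside the earlier step, the same swap behaves alike on the two cores, with no difference that can be told apart between the steps: the same change on two cores in this assay, a 1.3-fold lower number (0.12 log units; within the scatter) from compound 1 to compound 2 and a 1.2-fold lower number (0.07 log units; within the scatter) from compound 3 to compound 4, 1.1-fold (0.05 log units) apart, within the scatter of two such steps This shows only that the swap leaves the number within the scatter on both cores; it does not show that the same would hold on a further core, and with the halogen placed differently on each core, the effect of the core cannot be separated from that of the place on the ring, nor does the pair say anything about why the steps are alike.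

As far as these compounds go, what stays open is whether a group of another kind on this aromatic carbon, such as a methoxy group, a nitrile or an amine, would move the number beyond the scatter on either core. All four compounds carry the methyl ester, and whether a carboxylic acid or an amide in its place would alter the number on either core is also unanswered.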